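The source may hold more compounds than are shown below. What is called first, only, known or untested is meant among the compounds shown, and "the series" means these compounds.

Measured in a functional assay on LNCaP cells (Homo sapiens) for cytotoxicity (on this read-out higher numbers stand for weaker inhibition and lower numbers for stronger inhibition), so far:
compound 1, `O=C(Nc1ccc(-c2nc(N3CC4CCC(C3)O4)c3sccc3n2)cc1)NC1CC1`: 40 nM
compound 2, `CS(=O)(=O)N1CCN(Cc2cc3nc(-c4ccc(NC(=O)NC5CC5)cc4)nc(N4CC5CCC(C4)O5)c3s2)CC1`: 32 nM

Within the data shown here, compound 2 stands at 32 nM in this assay, and the only other measured number, from compound 1, sits within the scatter of it; the single measured step is a 1.3-fold lower number from compound 1 to compound 2 (0.10 log units; within the scatter). Compound 3 is `CN1CCN(Cc2cc3nc(-c4ccc(NC(=O)NC5CC5)cc4)nc(N4CC5CCC(C4)O5)c3s2)CC1`; relative to compound 2 the change is methyl in place of methylsulfonyl on an amine nitrogen in a ring. Among the measured compounds shown here, no measured step touches this ring nitrogen, so the step from compound 1 to compound 2 is only loose guidance and it was within the scatter. Compound 3 is therefore expected near compound 2, at 35 nM (range 12 nM to 100 nM), a step of a 1.1-fold higher number from compound 2 to compound 3 (0.04 log units; within the scatter) expected to stay within the scatter.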

Compound 3, half-maximal inhibitory concentration: 400 nM
Compound 3: middle estimate off by 11-fold (1.06 log units), on the low side; measured number outside the range, above it.
By their numbers in this assay, from the lowest: compounds 2 and 1 (each within the scatter of the next); then compound 3.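

In this assay, among these compounds, the group on this amine nitrogen in a ring matters strongly: methyl in place of methylsulfonyl gives a 13-fold higher number from compound 2 to compound 3 (1.10 log units; beyond the scatter), a change the earlier compounds gave no sign of. The side chain is therefore not neutral in itself: a 1.3-fold lower number from compound 1 to compound 2 (0.10 log units; within the scatter) for the methylsulfonyl form, while the 4-methylpiperazin-1-yl form gives a 10-fold higher number from compound 1 to compound 3 (1.00 log units; beyond the scatter) on the same core. Nothing available explains this difference.

Open, from the compounds shown here alone, is whether an acetyl, an ethyl or a bare ring amine on this nitrogen would sit nearer compound 2 or compound 3.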